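This account rests on a few compounds, and the source may have more. Where it says the series, first, only, none or still open, it means among the compounds named here.

Compound 1 `O=C(Nc1ccc(-c2noc(-c3cccc(NS(=O)(=O)c4cccc(Cl)c4)c3)n2)c(Cl)c1)c1cccnc1` and compound 2 `NS(=O)(=O)c1ccc(S(=O)(=O)Nc2cccc(-c3nc(-c4ccc(NC(=O)c5cccnc5)cc4Cl)no3)c2)cc1` share one core and differ only in the aryl group on the sulfonyl sulfur. In a functional assay on MDA-MB-231 cells (Homo sapiens) for antiproliferative activity, read by MTT assay, with a stated time of 72 h (on this read-out lower numbers stand for stronger inhibition and higher numbers for weaker inhibition), compound 1 reaches only the limit of the assay, > 10000 nM. In this assay compound 2 likewise stops at the limit, > 10000 nM. The step that the two limits leave unreadable from compound 1 to compound 2 thus cannot be read in size, as the limit of > 10000 nM in this assay, at which 2 of the 2 values shown sit, shows. Compound 3 `O=C(Nc1ccc(-c2noc(-c3cccc(NS(=O)(=O)c4ccc(C(F)(F)F)cc4)c3)n2)c(Cl)c1)c1cccnc1` has not yet been measured; it differs from compound 2 by trifluoromethyl in place of sulfamoyl on an aromatic carbon. For the measured compounds named here, the single measured step that bears on this position, from compound 1 to compound 2, gives no readable size, and with both values sitting at the limit no direction beyond the scatter can be drawn from it. The step that the limit leaves unreadable from compound 2 to compound 3 is therefore expected to be small. Compound 3 is accordingly estimated at 15000 nM, within a range from 4000 nM to 60000 nM, with a limit rather than a number the most likely outcome.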

Compound 3, half-maximal inhibitory concentration: > 10000 nM
Compound 3: a limit, no number; the forecaster's own chance of this, stated with the estimate: 75%; the middle value lies beyond the limit too.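

No step among compound 1, compound 2 and compound 3 can be read in size, as all three stop at a limit of the assay: the limit of > 10000 nM in this assay, at which 3 of the 3 values shown sit.

The compounds shown leave open what size or direction a change of the aryl group on the sulfonyl sulfur has in this assay.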